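The source may hold more compounds than are shown below. What is called first, only, known or untested is meant among the compounds shown, and "the series" means these compounds.

Compounds measured so far:
compound 1, `O=C(Nc1ccc(-n2ncc3c(C(F)(F)F)cccc32)cc1)Nc1ccc(Cl)c(C(F)(F)F)c1`, with 3000 nM
compound 2, `O=C(Nc1ccc(-n2ncc3c(F)cccc32)cc1)Nc1ccc(Cl)c(C(F)(F)F)c1`, with 9800 nM

In a functional assay on LoVo cells (Homo sapiens) for cytotoxicity, read by MTT assay, with a stated time of 72 h (a higher number here means a weaker inhibitor, a lower number a stronger inhibitor), compound 1 gives 3000 nM, the lower of the two numbers seen; compound 2 gives 9800 nM, and the step of a 3.3-fold higher number from compound 1 to compound 2 (0.51 log units; beyond the scatter) concerns a substituent on the shared core. Compound 3, `O=C(Nc1ccc(-n2ncc3c(C(F)(F)F)cccc32)cc1)Nc1ccc(C(F)(F)F)cc1`, arises from compound 1 by a change elsewhere: 4-(trifluoromethyl)phenyl in place of 4-chloro-3-(trifluoromethyl)phenyl on an amide-type nitrogen. Among the compounds with values here, no measured step touches this urea-side aryl group, so the only step known, from compound 1 to compound 2, offers scale but not direction. Within the data shown here, a substituent is lost and another is moved on this ring, and with no precedent here the expectation is a modest loss rather than a gain, with wide uncertainty. Compound 3 is therefore expected to give about 6000 nM in this assay, within 2000 nM to 20000 nM. This estimate corresponds to an expected step of a 2.0-fold higher number from compound 1 to compound 3 (0.30 log units; within the scatter).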

Compound 3, half-maximal inhibitory concentration: 2200 nM
Estimate against measurement, compound 3: 2.7-fold (0.44 log units) above, and the stated range covers the measured number.
By their numbers in this assay, from the lowest: compounds 3 and 1 (each within the scatter of the next); then compound 2.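

In this assay, within the data shown here, the first change on the aryl group carried by the amide-type nitrogen, 4-(trifluoromethyl)phenyl in place of 4-chloro-3-(trifluoromethyl)phenyl, gives a 1.4-fold lower number from compound 1 to compound 3 (0.13 log units; within the scatter), so this pair shows that the two aryl groups cannot be told apart in this assay. Among these compounds, the only step beyond the scatter thus remains the one on the shared core, a 3.3-fold higher number from compound 1 to compound 2 (0.51 log units; beyond the scatter), although two compounds and one change at each place are too few to support a wider pattern. Nothing available explains the match between compound 1 and compound 3.

Going by these compounds, it remains open whether an unsubstituted phenyl, a methoxy group or an amine on this aryl ring would leave the number unchanged. On these data alone, it is also open whether fluoro in place of trifluoromethyl on the core would give a similar step with the aryl group of compound 3.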